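Adding chloro to compound 2: working notes

A few compounds are considered here, and "the series" means these few. Any claim that something is new, unique, unknown or untested is made for them only; others in the source may bear on it.

Measured in a functional assay on NALM-6 cells (Homo sapiens) for cytotoxicity, read by luminescence and CellTiter-Glo, with a stated time of 3 days; a higher number here means a weaker inhibitor, a lower number a stronger inhibitor:
- compound 1 `N#Cc1ccc(NC(=O)c2cc(Cl)ccc2O)c(Cl)c1`: 730 nM
- compound 2 `O=C(Nc1ccc(OC(F)(F)F)cc1)c1cc(F)ccc1O`: 1210 nM
- compound 3 `O=C(Nc1cc(Cl)cc(Cl)c1)c1cc(F)ccc1O`: 1440 nM

In this assay, compound 2 gives 1210 nM, which lies within the scatter of both compound 1 and compound 3. The three values therefore support no ranking.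

The next compound is compound 4 `O=C(Nc1ccc(OC(F)(F)F)c(Cl)c1)c1cc(F)ccc1O`. It has chloro in place of hydrogen on an aromatic carbon of compound 2, ortho to a trifluoromethoxy group and meta to a large group: chloro in place of hydrogen on an aromatic carbon.

Going by the values given here, no measured pair differs in one place, so the effect of this change has not been isolated. Compound 1, which carries chloro on the same side of the amide, gives 730 nM. Compound 3, also chlorinated on that side, gives 1440 nM. Neither value separates from compound 2, so only a small shift is expected, with a slight lean toward a lower number in this assay. The expected change is a 1.4-fold lower number from compound 2 to compound 4 (0.15 log units; within the scatter), not clearly beyond the scatter. For compound 4 the estimate is 850 nM, with an expected range of 350 nM to 2000 nM.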

Compound 4, half-maximal inhibitory concentration: 1000 nM
Compound 4: middle estimate off by 1.2-fold (0.07 log units), on the low side; low and high end bracket the measured number.
By their numbers in this assay, from the lowest: compounds 1, 4, 2 and 3 (each within the scatter of the next).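

In this assay the series now has its first step in one place, with a 1.2-fold lower number from compound 2 to compound 4 (0.08 log units; within the scatter) as the result of chloro in place of hydrogen on an aromatic carbon. This carbon, ortho to a trifluoromethoxy group and meta to a large group, therefore accepts chloro with no shift beyond the scatter, so the change leaves the number of compound 2 effectively in place. No separate measurement bears on this result.

The compounds shown leave open whether an amine or a carboxylic acid on this same carbon would give a step beyond the scatter. They also leave open whether chloro here would act alike with the trifluoromethoxy group replaced by a nitrile, since compound 1 and compound 3 each differ from compound 4 in more than one place.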